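The compounds below may be only part of what the source reports. "The series", "measured", "known", "first", "only" and "open" are said of these compounds alone.

Measured compounds in a functional assay on A2780 cells (Homo sapiens) for inhibition, with a stated time of 72 h; on this read-out lower numbers stand for stronger inhibition and higher numbers for weaker inhibition:

Compound 1 `CC1(C)CC(C)(C)c2cc(NC(=O)Nc3ccc([N+](=O)[O-])cc3)ccc2O1` gives 4100 nM.
Compound 2 `CC1(C)CC(C)(C)c2cc(NC(=O)Nc3ccc(C(F)(F)F)cc3)ccc2O1` gives 3600 nM.
Compound 3 `CCC1(CC)CC(C)(C)Oc2ccc(NC(=S)Nc3ccc([N+](=O)[O-])cc3)cc21` gives 3690 nM.

Compound 1 and compound 2 share a core and differ only by trifluoromethyl in place of nitro on an aromatic carbon; the step was a 1.1-fold lower number from compound 1 to compound 2 (0.06 log units; within the scatter). Compound 3 is built on a different core; the difference between the two cores is not broken down here. Its value lies close to those of compound 1 and compound 2, all three within the scatter of one another, so no order among them can be stated.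

Compound 4 `CCC1(CC)CC(C)(C)Oc2ccc(NC(=S)Nc3ccc(C(F)(F)F)cc3)cc21` is the counterpart of compound 3 with trifluoromethyl in place of nitro on an aromatic carbon. The place of the change is the same, word for word, as in the step from compound 1 to compound 2, so this is the same change made on the second core. Among the measured compounds shown here, the one precedent for it on the first core stayed within the scatter, and since compound 3 sits at 3690 nM, the expectation for this assay is a step of about a 1.1-fold lower number from compound 3 to compound 4 (0.04 log units; within the scatter), also within the scatter. Compound 4 is therefore estimated at 3400 nM, with a range from 1700 nM to 7000 nM.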

Compound 4, half-maximal inhibitory concentration: 4700 nM
Compound 4: middle estimate off by 1.4-fold (0.14 log units), on the low side; low and high end bracket the measured number.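

In this assay, trifluoromethyl in place of nitro on the core of compound 3 gives a 1.3-fold higher number from compound 3 to compound 4 (0.11 log units; within the scatter), and set beside the same change on the core of compound 1, the two steps do not differ: the same change on two cores in this assay, a 1.1-fold lower number (0.06 log units; within the scatter) from compound 1 to compound 2 and a 1.3-fold higher number (0.11 log units; within the scatter) from compound 3 to compound 4, 1.5-fold (0.16 log units) apart, within the scatter of two such steps

On these two cores, then, the exchange of nitro for trifluoromethyl leaves the number within the scatter each time, and the small steps in opposite directions carry no readable sign of a core dependence. Among the compounds shown here, this rests on only two matched pairs, with neither step large enough to read, so it does not show that the change would stay as small on any other core, nor what the differences between the two cores contribute.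

Still open, on these data alone, is whether any other group on the same aromatic carbon, such as an amine, a carboxylic acid or a nitrile, would move the number beyond the scatter. Also open, as far as these compounds go, is whether a single change within the core, such as a longer chain, would do so.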